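A Larger Amine on a Shared Core

The source may report more compounds than this note shows. Statements on the series, on what has been measured and on what is new or still open speak of the compounds shown alone.

Compound 1 `CNc1nc(/C=C/c2ccco2)nc2ccsc12` gives 811000 nM in a functional assay on L02 cells (Homo sapiens) for inhibition, read by Griess assay, with stated times of 1 h and 24 h; on this read-out higher numbers stand for weaker inhibition and lower numbers for stronger inhibition.
Compound 2 `C(=C/c1ccco1)\c1nc(NCc2ccccc2)c2sccc2n1` reaches only the limit of this assay, > 1000000 nM.
Compound 3 `COc1cc(/C=C/c2nc(N(C)C)c3sccc3n2)cc(OC)c1OC` likewise stands at the limit of this assay, > 1000000 nM.

Compound 3 therefore has no number of its own, only the limit shared with another of the three compounds, (the limit of > 1000000 nM in this assay, at which 2 of the 3 values shown sit). Compound 4 `COc1cc(/C=C/c2nc(NCc3ccc(C)cc3)c3sccc3n2)cc(OC)c1OC` differs from it in one place: (4-methylbenzyl)amino in place of dimethylamino on an aromatic carbon. Among the compounds with values here, the one comparable measured step is an at least 1.2-fold higher number from compound 1 to compound 2 (0.09 log units; that floor lies within the scatter), where phenyl entered on a saturated chain carbon bound to a nitrogen on an aromatic ring and the number did not fall. A similar outcome is expected here, with a step that the limit leaves unreadable from compound 3 to compound 4. Compound 4 is estimated at 1500000 nM, most likely again reported only as a limit, within a range from 600000 nM to 5000000 nM.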

Compound 4, half-maximal inhibitory concentration: > 1000000 nM
Compound 4: no number, only a limit (the forecaster's own chance of this, stated with the estimate: 75%); the middle value is on the limit's open side.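

Compound 3 and compound 4 both stand only at a limit in this assay, and the step between them cannot be read. On these data alone, whether (4-methylbenzyl)amino in place of dimethylamino changes inhibition at all stays open.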